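The compounds below may be only part of what the source reports. "The series", "measured", "known", "first", "only" and "open" are said of these compounds alone.

Compound 1 `CC(=O)N1CCC(C(=O)N(CCCN2CCC(CNc3cc(C)ccn3)CC2)c2ccc(C)c(Cl)c2)CC1` gives 17900 nM in an ADME assay (Homo sapiens) for cytotoxicity; a higher number here means that more compound is tolerated, a lower number that less compound is tolerated. Compound 2 `CC(=O)N1CCC(C(=O)N(CCCN2CCC(Oc3ccccc3)CC2)c2ccc(C)c(Cl)c2)CC1` gives only a limit of the assay in this assay, > 56600 nM. Compound 3 `CC(=O)N1CCC(C(=O)N(CCCN2CCN(Cc3cnc(Cl)s3)CC2)c2ccc(C)c(Cl)c2)CC1` gives only a limit in this assay, > 52300 nM.

Compound 3 thus stands at a limit of this assay, one of two such limits among the three values shown (the limit of > 52300 nM in this assay, at which 1 of the 3 values shown sits). Among the measured compounds shown here, the single measured step, an at least 3.1-fold higher number from compound 1 to compound 2 (0.49 log units; beyond the scatter), concerns a different part of the shared core and ends at a limit itself, so it gives no direct guide to the present change. Compound 4 `CC(=O)N1CCC(C(=O)N(CCCN2CCN(Cc3ccccc3)CC2)c2ccc(C)c(Cl)c2)CC1` differs from compound 3 by phenyl in place of 2-chloro-1,3-thiazol-5-yl on a saturated chain carbon bound to an amine nitrogen in a ring. For the measured compounds named here, no measured step tests this exchange, so no movement beyond the scatter is expected, and the step that the limit leaves unreadable from compound 3 to compound 4 is estimated to be small. Compound 4 is expected to give about 55000 nM in this assay, probably again only as a limit, with a range from 20000 nM to 110000 nM.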

Compound 4, half-maximal cytotoxic concentration: 101000 nM
Estimate against measurement, compound 4: 1.8-fold (0.26 log units) below; the measured number falls inside the stated range.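

The change from compound 3 to compound 4 gives no readable step, because compound 3 has only a limit in this assay: the limit of > 52300 nM in this assay, at which 1 of the 4 values shown sits.

The compounds shown leave open whether phenyl in place of 2-chloro-1,3-thiazol-5-yl changes the result in this assay at all, and by how much.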